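Cell tolerance of amide variants around a shared core

The source may report more compounds than this note shows. Statements on the series, on what has been measured and on what is new or still open speak of the compounds shown alone.

Measured compounds:
Compound 1, `COc1ccc(-c2cnc(NC(=O)c3cccc(OC)c3)n2C)cc1`: in a toxicity assay on THP-1 cells (Homo sapiens) for inhibition (a higher number here means that more compound is tolerated, a lower number that less compound is tolerated), compound 1 gives > 100000 nM, which is a limit of the assay rather than a number.
Compound 2, `COc1ccc(-c2cnc(NC(=O)c3ccco3)n2C)cc1`: in this assay compound 2 gives > 100000 nM, again a limit.
Compound 3, `COc1ccc(-c2cnc(NC(=O)c3ccccc3Br)n2C)cc1`: in this assay compound 3 gives > 100000 nM, also a limit.

Compound 3 therefore stands at the limit, and so do both of its neighbours: the limit of > 100000 nM in this assay, at which 3 of the 3 values shown sit. The steps that involve compound 3, a step that the two limits leave unreadable from compound 1 to compound 3 and a step that the two limits leave unreadable from compound 2 to compound 3, as well as a step that the two limits leave unreadable from compound 1 to compound 2, cannot be sized, since both ends of each are limits.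

The unmeasured compound 4, `COc1ccc(-c2cnc(NC(=O)c3cccc(F)c3)n2C)cc1`, differs from compound 3 in one place: 3-fluorophenyl in place of 2-bromophenyl on a carbonyl carbon. All three measured variations of the group on the carbonyl carbon left the read-out at the limit, so no step beyond the scatter is expected here either; the estimated step that the limit leaves unreadable from compound 3 to compound 4 is small. Compound 4 is expected to give about 150000 nM, most likely again reported as a limit, with a range from 60000 nM to 400000 nM.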

Compound 4, half-maximal cytotoxic concentration: > 100000 nM
Compound 4 gave a limit, no number (the forecaster's own chance of this, stated with the estimate: 85%); the middle value lies beyond the limit too.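

Compound 4 stands at the limit like compound 1, compound 2 and compound 3, so none of its steps to them can be read: the limit of > 100000 nM in this assay, at which 4 of the 4 values shown sit.

The compounds shown leave open whether in this assay any other group on the carbonyl carbon would give a number rather than a limit.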